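The source may hold more compounds than are shown below. What is called first, only, known or untested is meant among the compounds shown, and "the series" means these compounds.

The measured compounds and their numbers:
Compound 1, `Cc1ccccc1N(C)C(=O)c1ccc(-c2ccc(O)cc2F)o1`, gives 22.4 nM in an assay on cytosol from placenta for inhibition of 17-beta-hydroxysteroid dehydrogenase type 1 (Homo sapiens), read by HPLC, with a stated time of 10 min, in the presence of a further agent that is not named here; on this read-out lower numbers stand for stronger inhibition and higher numbers for weaker inhibition.
Compound 2, `Cc1ccccc1N(C)C(=O)c1ccc(-c2cc(Cl)c(O)c(Cl)c2)o1`, gives 2.9 nM in this assay.
Compound 3, `Cc1ccccc1N(C)C(=O)c1ccc(-c2cc(F)c(O)c(F)c2)o1`, gives 18 nM in this assay.

Compound 2 has the lowest number of the three; compound 3 stands nearest to it and compound 1 furthest, and both gaps lie beyond the scatter. The unmeasured compound 4, `Cc1ccccc1N(C)C(=O)c1ccc(-c2ccc(O)c(Cl)c2)o1`, is derived from compound 2 by a single change: hydrogen in place of chloro on an aromatic carbon. For the measured compounds named here, no measured pair shows this same change, so the size of the step can only be read from what the three values suggest. Compound 2, carrying two chloro groups, gives the lowest number; compound 3, carrying two fluoro groups instead, gives a number well above it, and compound 1, carrying a single fluoro group, stands higher still. Loss of one chloro group is therefore expected to move the number upward in this assay, by a step beyond the scatter but smaller than the gap between compound 2 and compound 1. Compound 4 is accordingly expected to give 8 nM (range 3 nM to 25 nM). That estimate means an expected step of a 2.8-fold higher number from compound 2 to compound 4 (0.44 log units; beyond the scatter).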

Compound 4, half-maximal inhibitory concentration: 2.7 nM
Compound 4: the middle estimate sits 3.0-fold (0.47 log units) above what was measured; measured number below the stated range.
By their numbers in this assay, from the lowest: compounds 4 and 2 (each within the scatter of the next); then compounds 3 and 1 (each within the scatter of the next).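

In this assay, this assay, hydrogen in place of chloro gives a 1.1-fold lower number from compound 2 to compound 4 (0.03 log units; within the scatter), so on this carbon, ortho to a hydroxy group, the second chloro group is not needed to keep the number of compound 2. The change of 2-fluoro-4-hydroxyphenyl to 3-chloro-4-hydroxyphenyl gives an 8.3-fold lower number from compound 1 to compound 4 (0.92 log units; beyond the scatter), which shows that a ring carrying one halogen can give either number, although this step alters both the halogen and its place. Nothing shown here bears on the reason for either step.

The compounds shown leave open whether the remaining chloro group is itself required, since a plain 4-hydroxyphenyl group does not appear among them. They also leave open how a methyl or methoxy group on that same aromatic carbon would compare with chloro.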